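The compounds below may be only part of what the source reports. "The series", "measured", "known", "first", "only" and "open" are said of these compounds alone.

Measured so far:
Compound 1 `CCOC(=O)c1cnc(CC)nc1NN1C(=O)C=C(C)C1=O` — in a functional assay on Jurkat cells for inhibition of nuclear factor NF-kappa-B complex (Homo sapiens) (a higher number here means a weaker inhibitor, a lower number a stronger inhibitor), compound 1 gives 10000 nM.
Compound 2 `CCOC(=O)c1cnc(-c2ccccc2)nc1NN1C(=O)C=C(C)C1=O` — compound 2 gives 100 nM.
Compound 3 `CCOC(=O)c1cnc(-c2cccc(OC)c2)nc1NN1C(=O)C=C(C)C1=O` — compound 3 gives 5000 nM.

Compound 2 has the lowest number of the three. Its nearest neighbour is compound 3, with a 50-fold higher number from compound 2 to compound 3 (1.70 log units; beyond the scatter), and the furthest is compound 1, with a 100-fold lower number from compound 1 to compound 2 (2.00 log units; beyond the scatter). The next compound to measure is compound 4 `CCOC(=O)c1cnc(-c2ccsc2)nc1NN1C(=O)C=C(C)C1=O`, which differs from compound 2 in one place: thiophen-3-yl in place of phenyl on an aromatic carbon.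

For the measured compounds named here, two measured steps bear on this. The change from an ethyl to a phenyl ring brought a large gain, a 100-fold lower number from compound 1 to compound 2 (2.00 log units; beyond the scatter), so an aromatic ring at this position seems to matter. Adding a methoxy to that ring cost most of it, a 50-fold higher number from compound 2 to compound 3 (1.70 log units; beyond the scatter), so the ring tolerates little alteration. Going by the values given here, no measured compound carries a thiophen-3-yl, so the swap is untested. Compound 4 is therefore expected to give 300 nM, with a range from 60 nM to 2000 nM. That estimate amounts to an expected step of a 3.0-fold higher number from compound 2 to compound 4 (0.48 log units; beyond the scatter).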

Compound 4, half-maximal inhibitory concentration: 100 nM
Compound 4: middle estimate off by 3.0-fold (0.48 log units), on the high side; the measured number falls inside the stated range.
By their numbers in this assay, from the lowest: compounds 2 and 4 (each within the scatter of the next); then compounds 3 and 1 (each within the scatter of the next).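

In this assay the five-membered thiophen-3-yl ring, which carries a sulfur atom, can stand in for the six-membered phenyl ring (no change at the digits printed from compound 2 to compound 4 (within the scatter)), so this position does not require phenyl itself. The large gain over ethyl also appears with this second aromatic ring (a 100-fold lower number from compound 1 to compound 4 (2.00 log units; beyond the scatter)), and thiophen-3-yl also stands far ahead of 3-methoxyphenyl (a 50-fold lower number from compound 3 to compound 4 (1.70 log units; beyond the scatter)), so compound 3 goes against any idea that an aromatic ring alone is enough here. Nothing available explains why phenyl and thiophen-3-yl give matching numbers.

Still open, on these data alone, is whether a ring with a nitrogen atom, such as pyridine, or the isomeric thiophen-2-yl would match them. As far as these compounds go, it is also open whether a smaller group than methoxy on the phenyl ring, such as fluorine, would avoid the loss seen with compound 3.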